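This account rests on a few compounds, and the source may have more. Where it says the series, first, only, none or still open, it means among the compounds named here.

In an ADME assay on BHK-21 cells (Mesocricetus auratus) for cytotoxicity, read by MTT assay, with a stated time of 72 h (a lower number here means that less compound is tolerated, a higher number that more compound is tolerated), compound 3 (`NS(=O)(=O)c1ccc(N2N=C(c3ccc(Oc4ccccc4)cc3)CC2c2cccc(Cl)c2)cc1`) gives 9000 nM and sits at the low end, within the scatter of compound 1 (`NS(=O)(=O)c1ccc(N2N=C(c3ccc(Oc4ccccc4)cc3)CC2c2cccc(F)c2)cc1`) at 10000 nM while compound 2 (`NS(=O)(=O)c1ccc(N2N=C(c3ccc(OCc4ccccc4)cc3)CC2c2ccccc2F)cc1`) stands well apart at 90000 nM on the better tolerated side. Compound 4 (`NS(=O)(=O)c1ccc(N2N=C(c3ccc(Oc4ccccc4)cc3)CC2c2ccccc2F)cc1`) follows from compound 3 through 2-fluorophenyl in place of 3-chlorophenyl on a saturated ring carbon with 2-fluorophenyl in place of 3-chlorophenyl on a saturated ring carbon. Among the measured compounds shown here, the only measured halogen exchange, a 1.1-fold lower number from compound 1 to compound 3 (0.05 log units; within the scatter) for chloro in place of fluoro, was within the scatter. Compound 2 also bears 2-fluorophenyl but differs from compound 4 elsewhere, so its value is only a loose hint toward higher numbers. The expected change is therefore small, a 1.6-fold higher number from compound 3 to compound 4 (0.19 log units; within the scatter) as estimated, and no step beyond the scatter is firmly expected. Compound 4 is estimated at 14000 nM with 6000 nM to 40000 nM as its expected range.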

Compound 4, half-maximal cytotoxic concentration: 32000 nM
Estimate against measurement, compound 4: 2.3-fold (0.36 log units) below, within the range that was stated.
By their numbers in this assay, from the lowest: compounds 3 and 1 (each within the scatter of the next); then compound 4; then compound 2.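

In this assay, the place on the saturated ring carbon proves sensitive to the aryl substitution pattern: moving only the fluorine gives a 3.2-fold higher number from compound 1 to compound 4 (0.51 log units; beyond the scatter) and the full exchange gives a 3.6-fold higher number from compound 3 to compound 4 (0.55 log units; beyond the scatter), both beyond the scatter, whereas the halogen exchange alone, a 1.1-fold lower number from compound 1 to compound 3 (0.05 log units; within the scatter), stayed within it. With 2-fluorophenyl held constant, the group on the oxygen also matters, with a 2.8-fold lower number from compound 2 to compound 4 (0.45 log units; beyond the scatter). Nothing available here explains these steps. The compounds shown leave open whether 2-chlorophenyl or 2-methoxyphenyl on this carbon would follow 2-fluorophenyl.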